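This account rests on a few compounds, and the source may have more. Where it says the series, first, only, none or still open, it means among the compounds named here.

Measured in a physicochemical assay for solubility, read by nephelometry, in phosphate buffer, measured as kinetic solubility, at pH 6.5; a lower number here means a less soluble compound, a higher number a more soluble compound:

Compound 1 `COc1ccc(-c2cc(-c3cccc(S(C)(=O)=O)c3)cnc2N)cn1`: 25 ug/mL
Compound 2 `COc1ccc(-c2cc(-c3ccc(S(N)(=O)=O)cc3)cnc2N)cn1`: 12.5 ug/mL
Compound 3 `COc1ccc(-c2cnc(N)c(-c3ccc(OC)nc3)c2)cn1`: 25 ug/mL

Three compounds share a core and differ only in the group on the outer ring. In this assay compound 1 stands level with compound 3 at the digits shown, and together these two give the highest of the three numbers; compound 2 sits a little lower, yet that gap still lies within the usual scatter of repeated measurements, so none of the three can be called more or less soluble than another on this evidence.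

The next compound, compound 4 `COc1ccc(-c2cc(-c3cccc(C(N)=O)c3)cnc2N)cn1`, has not yet been measured. It differs from compound 1 in one place: carbamoyl in place of methylsulfonyl on an aromatic carbon. Going by the values given here, no step between two measured compounds here changes one group into another, so there is no measured step to lean on for the size of this change. Among the compounds with values here, the three values so far span a narrow band, and the change from methylsulfonyl to carbamoyl gives no reason in these data to expect a move out of that band.

The step of a 1.3-fold lower number from compound 1 to compound 4 (0.10 log units; within the scatter) is therefore expected to stay within the scatter. For compound 4 the estimate in this assay is 20 ug/mL, with a likely range from 8 ug/mL to 50 ug/mL.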

Compound 4, solubility: 12.5 ug/mL
Compound 4: the middle estimate sits 1.6-fold (0.20 log units) above what was measured; the measured number falls inside the stated range.
By their numbers in this assay, from the lowest: compounds 2, 4, 1 and 3 (each within the scatter of the next).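

In this assay, going by these compounds alone, carbamoyl in place of methylsulfonyl on an aromatic carbon, meta to a large group, gives the first step in this set that can be read as one change in one place (a 2.0-fold lower number from compound 1 to compound 4 (0.30 log units; within the scatter)). The two groups differ in what is counted on them, with methylsulfonyl carrying 0 hydrogen-bond donors and 2 hydrogen-bond acceptors and carbamoyl carrying 1 hydrogen-bond donor and 1 hydrogen-bond acceptor, yet this step stays within the usual scatter of repeated measurements, so the two compounds cannot be told apart in this assay. This is a single pair of compounds, and no measurement shown here bears on why the step has this size.

As far as these compounds go, it remains open whether a group of another kind at this place, such as an amine, a carboxylic acid or a longer chain, would give a step that clears the scatter. From the compounds shown here alone, it also remains open whether carbamoyl in place of methylsulfonyl would give a step of similar size on a different core.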